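Capping the phenol hydroxy of compound 3 with methyl

A few compounds are considered here, and "the series" means these few. Any claim that something is new, unique, unknown or untested is made for them only; others in the source may bear on it.

Measured in a functional assay on BV-2 cells (Mus musculus) for inhibition, read by Griess assay, with a stated time of 24 h; on this read-out higher numbers stand for weaker inhibition and lower numbers for stronger inhibition:
- compound 1 `C=CCc1ccc(O)c(-c2cc(CO)on2)c1`: > 200000 nM
- compound 2 `Oc1ccc(Br)cc1-c1ccn(-c2ccccc2)n1`: > 200000 nM
- compound 3 `Oc1ccc(Br)cc1-c1ccn(Cc2ccccc2)n1`: > 200000 nM

Compound 3 gives > 200000 nM in this assay, and this is a limit of the assay, not a number.

Compounds 1 and 2 offer no firmer reference, since the whole set stands at one ceiling: the limit of > 200000 nM in this assay, at which 3 of the 3 values shown sit. Among the measured compounds shown here, no true number is available for ranking the three, and no measured step exists to guide a prediction.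

Compound 4 `COc1ccc(Br)cc1-c1ccn(Cc2ccccc2)n1` keeps the core of compound 3 and changes one thing: methyl in place of hydrogen on an oxygen on an aromatic ring. This is methyl in place of hydrogen on an oxygen on an aromatic ring, or hydroxy to methoxy.

With nothing measured to build on, the expectation in this assay is no step beyond the scatter, and another limit is the most likely result. If a number does appear, it is expected on the side of stronger inhibition, as only that side of the limit can be read. The expected step is a number no higher from compound 3 to compound 4 (the limit leaves the size open).

For compound 4 the estimated value is 200000 nM, with an expected range of 60000 nM to 400000 nM.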

Compound 4, half-maximal inhibitory concentration: > 200000 nM
Compound 4 gave a limit, no number; the forecaster's own chance of this, stated with the estimate: 70%; the middle value sits exactly at the limit.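

Compound 3 and compound 4 both give a limit, not a number, so no step can be read between them. The whole set stands at one ceiling: the limit of > 200000 nM in this assay, at which 4 of the 4 values shown sit.

The compounds shown leave open how these four rank against one another, and what effect, if any, hydroxy to methoxy has on inhibition.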